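The source may report more compounds than this note shows. Statements on the series, on what has been measured and on what is new or still open speak of the compounds shown alone.

Measured compounds:

Compound 1 `COc1ccc(C2N=C(SCc3ccc(Cl)cc3)NC(C)=C2C(=O)Nc2ccc(F)cc2)cc1OC`: 5.7%
Compound 2 `CC1=C(C(=O)Nc2ccc(F)cc2)C(c2ccc([N+](=O)[O-])cc2)N=C(SCc2ccccc2)N1`: 7.2%
Compound 3 `CC1=C(C(=O)Nc2ccc([N+](=O)[O-])cc2)C(c2ccc(Br)cc2)N=C(SCc2ccccc2)N1`: 3.6%

All three were tested in a functional assay on the whole organism (artery, strain albino) with Rattus norvegicus as the target, with a stated time of 30 min, at a dose of 10 mg/kg by the oral route; a higher number here means more inhibition at the dose given (going by the name of the read-out), a lower number less inhibition. In this assay compound 3 gives 3.6%, the smallest of the three numbers, yet its gap to compound 1 and its gap to compound 2 both lie within the usual scatter, so no order among the three can be read from them; all three show only weak inhibition at the dose given.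

Compound 4 `CC1=C(C(=O)Nc2ccc([N+](=O)[O-])cc2)C(c2ccc(Br)cc2)N=C(SCc2ccc(Cl)cc2)N1` has not been measured. It differs from compound 3 in one place: chloro in place of hydrogen on an aromatic carbon. Cut one bond further out, the same difference reads benzylsulfanyl to (4-chlorobenzyl)sulfanyl. Among the measured compounds shown here, compound 1 also carries a (4-chlorobenzyl)sulfanyl group, but it differs from compound 3 in several other places as well, so its value says only that a compound bearing that group gave a number within the scatter of compound 3.

For the measured compounds named here, no step between measured compounds that differ in a single place is known, so there is nothing to anchor the size of this change. The expectation for compound 4 is a step of a number 1.4 percentage points higher from compound 3 to compound 4 (within the scatter) from compound 3, that is, no change beyond the scatter. Compound 4 is therefore estimated at 5% in this assay, with a likely range from 0% to 15%.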

Compound 4, a percentage reported as inhibition, in the whole organism at one dose (the size of the read-out at that dose, not a potency): 6.2%
Beside the measured number, compound 4's estimate is 1.2 percentage points below it, within the range that was stated.
By their numbers in this assay, from the lowest: compounds 3, 1, 4 and 2 (each within the scatter of the next).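

In this assay, among the compounds shown here, the comparison of compound 3 with compound 4 gives the first reading of a single change in this set: chloro in place of hydrogen on an aromatic carbon, para to a large group, comes out as a number 2.6 percentage points higher from compound 3 to compound 4 (within the scatter). Earlier, compound 1 could hint at the (4-chlorobenzyl)sulfanyl group only alongside several other differences, whereas here that group is the only difference. At this position, the added chlorine atom leaves the two compounds indistinguishable at the dose given, and both show only weak inhibition. No measurement here offers an explanation for this result.

One step within the scatter cannot show whether this position is insensitive to substitution in general, and a carboxylic acid or an amine in place of the chloro group would be a much more different test of it. On these data alone, it also remains open whether chloro would read the same way with the other groups on the shared core, such as those carried by compound 2.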